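The source may hold more compounds than are shown below. What is called first, only, known or untested is meant among the compounds shown, and "the series" means these compounds.

Compound 1 `C#CCSc1nc(Sc2nc3ccccc3s2)c(C#N)c(-c2cc(OC)c(OC)c(OC)c2)n1`: > 20000 nM
Compound 2 `C#CCSc1nc(Sc2nccs2)c(C#N)c(-c2ccc[nH]2)n1`: > 20000 nM

Of the compounds shown here, two have so far been tested in a functional assay on SMMC-7721 cells (Homo sapiens) for antiproliferative activity, read by MTT assay, with a stated time of 72 h; a lower number here means a stronger inhibitor, a higher number a weaker inhibitor. Compound 1 gives > 20000 nM, which is a limit of the assay rather than a measured number. Compound 2 likewise gives > 20000 nM, again a limit. Compound 1 therefore cannot be ranked against compound 2 on these numbers: the limit of > 20000 nM in this assay, at which 2 of the 2 values shown sit, and neither compound shows a measurable effect within the range the assay covers.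

Compound 3 `C#CCSc1nc(Sc2ccccn2)c(C#N)c(-c2cc(OC)c(OC)c(OC)c2)n1` has not yet been tested. It differs from compound 1 in one place: pyridin-2-yl in place of 1,3-benzothiazol-2-yl on a sulfur. Among the compounds with values here, no pair of measured compounds that differ in a single place is available, so there is no measured step to lean on. Both tested compounds sit only at a limit, and nothing in the numbers points to a gain. With that in mind, the step that the limit leaves unreadable from compound 1 to compound 3 is expected to be none beyond the scatter. The estimate for compound 3 in this assay is therefore 25000 nM, with a range from 8000 nM to 80000 nM, and it is expected that the assay will most likely again report only a limit.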

Compound 3, half-maximal inhibitory concentration: > 20000 nM
Compound 3: no number, only a limit (the forecaster's own chance of this, stated with the estimate: 75%); the middle value is on the limit's open side.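

In this assay compound 3 gives > 20000 nM, which is a limit and not a number. Within the data shown here, compound 1 also sits at a limit, so no step from compound 1 to compound 3 can be read. The compounds shown leave open whether pyridin-2-yl in place of 1,3-benzothiazol-2-yl on a sulfur changes activity at all, because every result stops at the same point: the limit of > 20000 nM in this assay, at which 3 of the 3 values shown sit.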